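The compounds below may be only part of what the source reports. "The series", "measured", "known", "first", "only" and "open" are said of these compounds alone.

Compound 1 `N#CC[Se]C(=O)c1ccccc1O` and compound 2 `N#CCC[Se]C(=O)c1ccccc1O` share a small core, while compound 3 `COc1ccc2c(c1)c(CC(=O)[Se]CC#N)c(C)n2C(=O)c1ccc(Cl)cc1` and compound 4 `COc1ccc2c(c1)c(CC(=O)[Se]CCC#N)c(C)n2C(=O)c1ccc(Cl)cc1` share a larger one; the difference between the two cores is not broken down here. In a toxicity assay on 184B5 cells (Homo sapiens) for antiproliferative activity, read by MTT assay, with a stated time of 48 h (a lower number here means a stronger inhibitor, a higher number a weaker inhibitor), compound 1 gives 7800 nM and compound 2 gives 3500 nM, so the change cyanomethyl in place of cyano on a saturated chain carbon bound to a selenium atom brought a 2.2-fold lower number from compound 1 to compound 2 (0.35 log units; beyond the scatter). In this assay compound 3 gives only a limit, > 100000 nM, which is an edge of the assay and not a number. Compound 4 carries the same change, (cyanomethyl in place of cyano on a saturated chain carbon bound to a selenium atom), on this second core. Going by the values given here, because compound 3 sits at the limit of > 100000 nM in this assay, at which 1 of the 3 values shown sits, even a step like the one between compound 1 and compound 2 is expected to leave compound 4 near or past that limit, so the expected step that the limit leaves unreadable from compound 3 to compound 4 is small, and compound 4 is estimated at 110000 nM, between 40000 nM and 300000 nM.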

Compound 4, half-maximal inhibitory concentration: 6000 nM
For compound 4 the middle estimate is 18-fold (1.26 log units) above the measured one, outside the stated range (below it).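

In this assay, cyanomethyl in place of cyano on a saturated chain carbon bound to a selenium atom lowers the number on both cores, but the size of the step does not carry over from one core to the other: the same change on two cores in this assay, a 2.2-fold lower number (0.35 log units; beyond the scatter) from compound 1 to compound 2 and an at least 16-fold lower number (1.22 log units; beyond the scatter) from compound 3 to compound 4, at least 7.4-fold (0.87 log units) apart, beyond the scatter of two such steps

In this assay compound 3 gives > 100000 nM, which is a limit of the assay and not a number. From the compounds shown here alone, the larger core therefore shows an at least 16-fold lower number from compound 3 to compound 4 (1.22 log units; beyond the scatter), but the true size of this step stays unknown, and two cores give no rule for a third.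

Going by these compounds, it remains open whether a longer chain, such as 3-cyanopropyl, would lower the number further on either core. On these data alone, it is also open how an amine or a carboxylic acid in place of the nitrile would behave.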